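This account rests on a few compounds, and the source may have more. Where it says the series, first, only, none or still open, it means among the compounds named here.

Compound 1 `CCN(CC)c1cc(C)nc(N(CC)c2c(Cl)cc(OC)cc2Cl)n1` is one of three compounds whose binding has been measured in an assay on isolated protein for binding affinity to corticotropin-releasing factor receptor 1 (Homo sapiens); a higher number here means a weaker inhibitor, a lower number a stronger inhibitor. In this assay compound 1 gives 15 nM. Compound 2 `CCN(CC)c1cc(C)nc(N(CC)c2c(Cl)cc(OC)cc2OC)n1` gives 10 nM, and compound 3 `CCN(CC)c1cc(C)nc(N(CC)c2c(Br)cc(C(C)C)cc2SC)n1` gives 26 nM. Among these three numbers compound 1 stands second highest, yet its nearest neighbour, compound 2, and its furthest, compound 3, both lie within the scatter of it, so the three compounds cannot be ranked against one another. For the measured compounds named here, the only step between two compounds that differ in a single place is a 1.5-fold lower number from compound 1 to compound 2 (0.18 log units; within the scatter), and it too stays within the scatter.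

Compound 4 `CCN(CC)c1cc(C)nc(N(CC)c2c(Cl)cc(Br)cc2Cl)n1` is not yet measured. It differs from compound 1 by bromo in place of methoxy on an aromatic carbon. Going by the values given here, no measured step swaps a methoxy for a bromo anywhere, so the evidence bearing on this change is thin: the one comparable exchange, chloro against methoxy on another aromatic carbon of the same ring, moved the number hardly at all, and compound 3, which carries a different group at the same place, remains within the scatter of compound 1. The expectation is therefore a step of a 1.3-fold higher number from compound 1 to compound 4 (0.12 log units; within the scatter), that is, no change beyond the scatter. Compound 4 is estimated at 20 nM, with a range from 7 nM to 60 nM.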

Compound 4, inhibition constant: 24 nM
The estimate for compound 4 lay 1.2-fold (0.08 log units) below the measured number; measured number inside the range.
By their numbers in this assay, from the lowest: compounds 2, 1, 4 and 3 (each within the scatter of the next, the first and the last beyond it).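

In this assay, the exchange at this place, on an aromatic carbon para to a large group and meta to two chloro groups, comes to a 1.6-fold higher number from compound 1 to compound 4 (0.20 log units; within the scatter). For the compounds shown here, this is the first direct reading at this position, as the only earlier single-place step concerned a different carbon of the ring. Methoxy carries a hydrogen-bond acceptor and bromo carries none, yet the two compounds cannot be told apart here, so within this pair neither the oxygen nor the methyl of the methoxy group shows any measurable contribution; nothing further bears on this result.

The compounds shown leave open how much this position would accept beyond these two small groups, for instance an amine, a carboxylic acid or a longer chain such as butoxy, any of which could move the number beyond the scatter. They also leave open whether bromo and methoxy would remain interchangeable at this place if one of the two chloro groups were replaced by a methoxy group.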